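The source may hold more compounds than are shown below. What is called first, only, known or untested is meant among the compounds shown, and "the series" means these compounds.

In an assay on cell membranes for binding affinity to Sigma non-opioid intracellular receptor 1 (Rattus norvegicus) (on this read-out higher numbers stand for weaker inhibition and lower numbers for stronger inhibition), compound 3 `COc1cccc2c1CCC(=O)N2CCCN1CCN(c2cccc(C#N)c2)CC1` gives 2470 nM, the highest of the three numbers in hand. Compound 1 `O=c1ccc2ccccc2n1CCCN1CCN(c2cccc(Cl)c2)CC1` gives 620 nM in this assay, and compound 2 `COc1cccc2c1CCC(=O)N2CCCN1CCN(c2cccc(C(F)(F)F)c2)CC1` gives 490 nM. Going by the values given here, the one measured step that touches the position in question, a 5.0-fold higher number from compound 2 to compound 3 (0.70 log units; beyond the scatter), is the only comparison that bears on the move to follow. Compound 4 `COc1cccc2c1CCC(=O)N2CCCN1CCN(c2cccc([N+](=O)[O-])c2)CC1` differs from compound 3 by nitro in place of cyano on an aromatic carbon. Among the compounds with values here, no measured pair exchanges a cyano for a nitro, so that single step speaks only indirectly: it shows that a change at this place can move this assay by a modest amount, and nothing in hand says whether the nitro will push the number up or down. On that footing compound 4 is expected to stay close to its starting point, with an estimated step of a 1.4-fold lower number from compound 3 to compound 4 (0.14 log units; within the scatter) in this assay. The estimate for compound 4 is 1800 nM, with a range from 600 nM to 5400 nM.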

Compound 4, half-maximal inhibitory concentration: 870 nM
Estimate against measurement, compound 4: 2.1-fold (0.32 log units) above; the measured number falls inside the stated range.
By their numbers in this assay, from the lowest: compounds 2, 1 and 4 (each within the scatter of the next); then compound 3.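

Going by these compounds alone, the step of a 2.8-fold lower number from compound 3 to compound 4 (0.45 log units; beyond the scatter) in this assay shows that nitro in place of cyano on this aromatic carbon lowers the number, a direction that the earlier compounds did not reveal. The step of a 1.8-fold higher number from compound 2 to compound 4 (0.25 log units; within the scatter) leaves nitro and trifluoromethyl within the scatter of each other at this place, whereas cyano lies beyond the scatter from both, so among these three groups on the shared core, cyano alone stands apart. Nothing in hand gives a reason for this difference between the groups. From the compounds shown here alone, how an amine or a carboxylic acid would read at this place remains open. Also open, going by these compounds, is whether cyano would stand apart in the same way on another core, since compound 1 differs from the other compounds in more than one place.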